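The source may report more compounds than this note shows. Statements on the series, on what has been measured and on what is new or still open speak of the compounds shown alone.

Measured so far:
compound 1 `OC[C@H]1O[C@@H](n2cnc3c(NCc4ccccc4)nccc32)C[C@@H]1O`: > 9 mg/kg
compound 2 `[N-]=[N+]=Nc1nccc2ncn([C@H]3C[C@H](O)[C@@H](CO)O3)c12`: > 9 mg/kg
compound 3 `Sc1[nH]ccc2ncnc1-2`: 8 mg/kg

In a functional assay on the whole organism (Pleural cavity) with Rattus norvegicus as the target (on this read-out higher numbers stand for an effect only at larger amounts of compound and lower numbers for an effect already at smaller amounts), compound 1 gives only a limit, > 9 mg/kg. For compound 2 the result is likewise a limit, > 9 mg/kg. Within the data shown here, compound 3 is the one compound with an actual number, 8 mg/kg. Among the measured compounds shown here, compound 1 therefore stands at the limit of > 9 mg/kg in this assay, at which 2 of the 3 values shown sit, and no measured step connects it to any other compound. Compound 4 `Nc1nccc2c1ncn2[C@H]1C[C@H](O)[C@@H](CO)O1` differs from compound 1 in a single place: hydrogen in place of benzyl on a nitrogen on an aromatic ring. For the measured compounds named here, with no measured step of this kind to lean on, only a modest shift, or none beyond the usual scatter, is expected for the step of a number no higher from compound 1 to compound 4 (the limit leaves the size open). Compound 4 is expected to give about 9 mg/kg in this assay, within a range from 4.5 mg/kg to 18 mg/kg.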

Compound 4, dose for half-maximal effect: 10 mg/kg
For compound 4 the middle estimate is 1.1-fold (0.05 log units) below the measured one; measured number inside the range.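

Compound 1 gives only a limit, so no size can be read for the change from compound 1 to compound 4: the limit of > 9 mg/kg in this assay, at which 2 of the 4 values shown sit.

The compounds shown leave open how far going from benzylamino to amino shifts the result in this assay.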